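Diethylaminoethyl in Place of Methylpiperazinyl on the Side Chain

The source may hold more compounds than are shown below. What is called first, only, known or untested is meant among the compounds shown, and "the series" means these compounds.

Compound 1, `Cn1c(N)c(-c2nc3ccccc3[nH]2)c2nc(C#N)c(C#N)nc21`: in an ADME assay on HEK293 cells (Homo sapiens) for cytotoxicity, read by MTT assay, with a stated time of 48 h (a lower number here means a stronger inhibitor, a higher number a weaker inhibitor), compound 1 gives > 50000 nM, which is a limit of the assay.
Compound 2, `CCn1c(N)c(-c2nc3ccccc3[nH]2)c2nc(C#N)c(C#N)nc21`: in this assay compound 2 gives > 50000 nM, again a limit.
Compound 3, `CN1CCN(CCn2c(N)c(-c3nc4ccccc4[nH]3)c3nc(C#N)c(C#N)nc32)CC1`: in this assay compound 3 gives 10900 nM.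

Going by the values given here, compound 3 therefore stands as the only true number among the three measured compounds; the other two sit at the limit of > 50000 nM in this assay, at which 2 of the 3 values shown sit. The step that the two limits leave unreadable from compound 1 to compound 2 cannot be read, since both ends are limits. Among the compounds with values here, the steps of an at least 4.5-fold lower number from compound 1 to compound 3 (0.66 log units; beyond the scatter) and an at least 4.5-fold lower number from compound 2 to compound 3 (0.66 log units; beyond the scatter) are both at least modest, and they are the only steps that bear on the side chain at this position.

Compound 4, `CCN(CC)CCCCn1c(N)c(-c2nc3ccccc3[nH]2)c2nc(C#N)c(C#N)nc21`, differs from compound 3 by 2-(diethylamino)ethyl in place of 4-methylpiperazin-1-yl on a saturated chain carbon, two bonds along the chain from an aromatic nitrogen. Within the data shown here, no measured step exchanges one amine-bearing chain for another with a number at both ends, so the two readable steps say only that a chain of this kind brings the value down from a limit to a number. On that basis the author expects no step beyond the scatter, a 1.1-fold higher number from compound 3 to compound 4 (0.04 log units; within the scatter). For compound 4 the expected value in this assay is 12000 nM, with a range from 4000 nM to 50000 nM.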

Compound 4, half-maximal inhibitory concentration: 5370 nM
Compound 4: middle estimate off by 2.2-fold (0.35 log units), on the high side, and the stated range covers the measured number.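

In this assay, the step of a 2.0-fold lower number from compound 3 to compound 4 (0.31 log units; beyond the scatter) is the only one in the series with a true number at both ends, and it shows that two amine-bearing side chains on the shared core need not read alike. The exchange of 4-methylpiperazin-1-yl for 2-(diethylamino)ethyl, on a saturated chain carbon two bonds along the chain from an aromatic nitrogen, moves the value beyond the scatter, although the two groups count the same heavy atoms. Against the shorter chains without an amine, the diethylamino chain gives an at least 9.3-fold lower number from compound 2 to compound 4 (0.96 log units; beyond the scatter) and an at least 9.3-fold lower number from compound 1 to compound 4 (0.96 log units; beyond the scatter), and both sizes remain lower bounds only: the limit of > 50000 nM in this assay, at which 2 of the 4 values shown sit.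

The change removes the ring and lengthens the chain in one step, so the compounds shown cannot separate the two, and a 4-(4-methylpiperazin-1-yl)butyl chain or a shorter 2-(diethylamino)ethyl chain on the aromatic nitrogen would be needed to do so. They also leave open how a morpholine or a piperidine at the end of the chain would read in this assay.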